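This account rests on a few compounds, and the source may have more. Where it says the series, first, only, none or still open, it means among the compounds named here.

Compound 1 `COc1cc(OC)c(OC)cc1/C=C/COC(=O)/C=C/c1ccc(Br)cc1` was tested in a functional assay on the whole organism (strain Kunming) with Mus musculus as the target, with a stated time of 0.5 h, at a dose of 300 mg/kg by the intraperitoneal route (a lower number here means a stronger effect, a higher number a weaker effect of the compound at the dose given), where compound 1 gives 100%. A second compound, compound 2 `COc1cc(OC)c(OC)cc1/C=C/COC(=O)/C=C/c1cc(OC)c(OC)c(OC)c1`, gives 100% in this assay. These two values are level at the digits shown and lie within the scatter of each other, so compound 1 stands level with its nearest neighbour, compound 2, and neither can be called the stronger. Compound 3 `COc1cccc(/C=C/C(=O)OC/C=C/c2cc(OC)c(OC)cc2OC)c1` has not yet been measured. Compared with compound 1, it carries 3-methoxyphenyl in place of 4-bromophenyl on a double-bonded chain carbon bound to a double-bonded chain carbon. Going by the values given here, no step between measured compounds is available to show what such a change does, so the expectation for compound 3 rests on the value of compound 1 alone. The step of a number 5 percentage points lower from compound 1 to compound 3 (within the scatter) is expected to be none beyond the scatter. The value for compound 3 in this assay is estimated at 95%, within a range from 70% to 100%.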

Compound 3, a percentage reported as activity, at one dose (the size of the read-out at that dose, not a potency): 100%
Compound 3: middle estimate off by 5 percentage points, on the low side; measured number inside the range.
By their numbers in this assay, from the lowest: compounds 1, 2 and 3 (each within the scatter of the next).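

In this assay there is no change at the digits printed from compound 1 to compound 3 (within the scatter) when 3-methoxyphenyl takes the place of 4-bromophenyl on a double-bonded chain carbon bound to a double-bonded chain carbon. Going by these compounds alone, this is the first direct reading at this position, and it shows that this exchange, which removes the bromine and brings in an oxygen counted as a hydrogen-bond acceptor, does not shift the read-out at this one dose. No measured information is available to explain this outcome.

Going by these compounds, it remains open whether a group of a different kind at this place, such as an amine or a carboxylic acid, would move the number. A reading at a single dose also leaves open whether compound 1 and compound 3 would still match at other doses.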